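From a Fluoro Group to a Methylpiperidine Ring

The compounds below may be only part of what the source reports. "The series", "measured", "known", "first", "only" and "open" are said of these compounds alone.

Of the compounds shown here, two sharing one core have been measured so far. Compound 1 `Fc1ccc(Nc2nccc(-c3ccncc3)n2)cc1` was tested in a functional assay for inhibition, with Homo sapiens as the target (on this read-out lower numbers stand for stronger inhibition and higher numbers for weaker inhibition), where compound 1 gives 1900 nM. Compound 2 `CCOC(=O)c1cccc(Nc2nccc(-c3ccccn3)n2)c1`, which carries a different arrangement of its outer groups, was tested in the same way, and compound 2 gives 3000 nM in this assay. The two numbers lie within the usual scatter of each other, so compound 1 cannot be called the more potent of the pair; it simply shows the smaller of the two values, and nothing beyond that can be read from them.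

Compound 3 `CC1CCN(c2ccc(Nc3nccc(-c4ccncc4)n3)cc2)CC1` has not yet been measured. It differs from compound 1 in one place: 4-methylpiperidin-1-yl in place of fluoro on an aromatic carbon. Within the data shown here, no measured pair in this set shows a change of comparable kind, so there is no precedent to lean on for the size of the step. The account therefore treats the expected outcome as open. The step from compound 1 to compound 3 is estimated as a 1.9-fold lower number from compound 1 to compound 3 (0.28 log units; within the scatter), and for compound 3 the expected value in this assay is 1000 nM, with a plausible range from 250 nM to 4000 nM.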

Compound 3, half-maximal inhibitory concentration: 600 nM
Beside the measured number, compound 3's estimate is 1.7-fold (0.22 log units) above it; low and high end bracket the measured number.
By their numbers in this assay, from the lowest: compound 3; then compounds 1 and 2 (each within the scatter of the next).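

Among these compounds, the change of fluoro to 4-methylpiperidin-1-yl, on an aromatic carbon para to a large group, gives in this assay the first single-place comparison in this set (a 3.2-fold lower number from compound 1 to compound 3 (0.50 log units; beyond the scatter)), a modest step that lies beyond the scatter. The earlier pair could not show this, as compound 1 and compound 2 differ in more than one place and their numbers lie within the scatter of each other; this position is now seen to tolerate a group of seven heavy atoms with a six-membered non-aromatic ring in place of a single fluorine, and the number falls rather than rises. The data offer no measurement that would account for this step, so the result stands as an observation without an explanation.

What the compounds shown leave open is which part of the new group goes with the lower number: the ring nitrogen, the ring itself or the methyl, as a plain piperidine ring, a morpholine ring or an open-chain dimethylamino group on the same carbon would help to tell. Also open, as far as these compounds go, is whether the same exchange would give a step of similar size on a compound that carries a pyridin-2-yl group in place of the pyridin-4-yl group of compound 1.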